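The source may hold more compounds than are shown below. What is called first, only, known or untested is meant among the compounds shown, and "the series" means these compounds.

Compound 1 `O=c1cc(Cn2cc(CCCO)nn2)c2ccc(O)cc2o1`, compound 2 `CCCCCCc1ccc(-c2cn(Cc3cc(=O)oc4cc(O)ccc34)nn2)cc1` and compound 3 `Cc1ccc(S(=O)(=O)NCc2cn(Cc3cc(=O)oc4cc(O)ccc34)nn2)cc1` share one core and were all tested in a functional assay on HeLa cells (Homo sapiens) for inhibition, read by MTT assay, with a stated time of 72 h; a lower number here means a stronger inhibitor, a higher number a weaker inhibitor. In this assay compound 1 gives 90200 nM, compound 2 gives 8730 nM and compound 3 gives 55700 nM. Among these three numbers compound 3 has the second highest; its nearest neighbour is compound 1, whose number is higher by a margin that lies within the scatter of the assay, while compound 2 sits furthest away, with a number lower by a margin beyond the scatter.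

Compound 4 `O=c1cc(Cn2cc(CNS(=O)(=O)c3ccc([N+](=O)[O-])cc3)nn2)c2ccc(O)cc2o1` has not yet been measured. It differs from compound 3 in a single place: nitro in place of methyl on an aromatic carbon. Among the compounds with values here, no pair of measured compounds shows this particular exchange, so there is no step on which to rest a firm expectation. In that absence, the step from compound 3 to compound 4 is expected to be small, a 1.1-fold lower number from compound 3 to compound 4 (0.05 log units; within the scatter), with no clear direction and quite possibly nothing beyond the scatter. Compound 4 is therefore estimated to give 50000 nM in this assay, with a plausible range from 20000 nM to 130000 nM.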

Compound 4, half-maximal inhibitory concentration: > 100000 nM
Compound 4: a limit, no number; the forecaster's own chance of this, stated with the estimate: 15%; at least 2.0-fold (0.30 log units) between middle value and limit.
By their numbers in this assay, from the lowest: compound 2; then compounds 3 and 1 (each within the scatter of the next). At a limit, above all of these: compound 4.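

In this assay compound 4 gives > 100000 nM, which is a limit of the assay and not a number. Within the data shown here, the exchange of 4-methylphenyl for 4-nitrophenyl, with the nitro on an aromatic carbon para to a large group, gives the first reading of any change at this position, and it comes out as an at least 1.7-fold higher number from compound 3 to compound 4 (0.25 log units; that floor lies within the scatter); it therefore shows that nitro here brings no gain over methyl, but the step has a floor rather than a size, and that floor alone does not carry it beyond the scatter. The reading ends at the top of the measured range, and this is all that can be said of how far the step extends: the limit of > 100000 nM in this assay, at which 1 of the 4 values shown sits.

As far as these compounds go, the actual value of compound 4 stays open, and with it the question of whether this exchange is a small step or a large one. Also open, from the compounds shown here alone, is what other groups on the same aromatic carbon would do, such as an amine, a methoxy group, a carboxylic acid or a longer chain like the hexyl chain, and whether any of them would lower the number.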